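A few compounds are considered here, and "the series" means these few. Any claim that something is new, unique, unknown or untested is made for them only; others in the source may bear on it.

Measured compounds:
compound 1, `COc1ccc(-c2cnc(NC(=O)c3ccccc3F)n2C)cc1`: > 100000 nM
compound 2, `Cn1c(-c2ccccc2)cnc1NC(=O)c1ncc[nH]1`: > 100000 nM
compound 3, `COc1ccc(-c2nc3ncc(-c4ccc(F)cc4)cc3[nH]2)cc1`: > 100000 nM

The measurements come from a toxicity assay on THP-1 cells (Homo sapiens) for inhibition; on this read-out higher numbers stand for lower toxicity in this test and lower numbers for higher toxicity in this test. In this assay compound 1 gives only a limit, > 100000 nM, and no number. Compound 2 likewise reaches only a limit, > 100000 nM. Compound 3 too is reported only as a limit, > 100000 nM. All three therefore sit at the same point, (the limit of > 100000 nM in this assay, at which 3 of the 3 values shown sit), so no ordering among them can be drawn and compound 1 cannot be placed above or below the other two; it stands where every measured compound stands.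

The compound that follows is compound 4, `COc1ccc(-c2cnc(NC(=O)c3cnco3)n2C)cc1`, which has not yet been measured in this assay. It differs from compound 1 in one place: 1,3-oxazol-5-yl in place of 2-fluorophenyl on a carbonyl carbon.

Going by the values given here, no step between two measured compounds exists here that could be used as a guide for the size of this change. Since compound 1 is known only as the limit > 100000 nM, and the shared picture is the limit of > 100000 nM in this assay, at which 3 of the 3 values shown sit, the step of a number no higher from compound 1 to compound 4 (the limit leaves the size open) is expected to be none beyond the scatter, with compound 4 most likely again reported as a limit rather than a number. Compound 4 is accordingly estimated at 100000 nM, within a range from 50000 nM to 300000 nM.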

Compound 4, half-maximal cytotoxic concentration: > 100000 nM
Compound 4: no number, only a limit; the forecaster's own chance of this, stated with the estimate: 85%; the middle value sits exactly at the limit.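

In this assay compound 4 gives only a limit, > 100000 nM, and compound 1 is also known only as a limit, so no step can be read between compound 1 and compound 4. The compounds shown leave open whether 1,3-oxazol-5-yl in place of 2-fluorophenyl alters toxicity in this assay at all, because all values share one limit: the limit of > 100000 nM in this assay, at which 4 of the 4 values shown sit.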